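A few compounds are considered here, and "the series" means these few. Any claim that something is new, unique, unknown or untested is made for them only; others in the source may bear on it.

In a functional assay on MCF7 cells (Homo sapiens) for antiproliferative activity, read by CCK-8 assay, with a stated time of 72 h (on this read-out higher numbers stand for weaker inhibition of growth and lower numbers for stronger inhibition of growth), compound 1 (`CCC1C(=O)N(C)c2cnc(-n3ccc4cc(C(=O)NC(C)C)ccc43)nc2N1c1ccn(C)n1`) gives 8420 nM as the highest number of the three measured compounds. That makes it the weakest growth inhibitor among them, beyond the scatter from both of the others. Compound 2 (`CC[C@@H]1C(=O)N(C)c2cnc(Nc3ccc(S(=O)(=O)NC4CCCC4)cc3)nc2N1C1CCCC1`) gives 688 nM and compound 3 (`CC[C@@H]1C(=O)N(C)c2cnc(-n3ccc4cc(C(=O)NCC(C)C)ccc43)nc2N1C1CCCC1`) gives 953 nM and these two values lie within the usual scatter of each other. Compound 4 (`CCC1C(=O)N(C)c2cnc(-n3ccc4cc(C(N)=O)ccc43)nc2N1c1ccn(C)n1`) has yet to be measured. It differs from compound 1 in one place (hydrogen in place of isopropyl on an amide-type nitrogen): hydrogen in place of isopropyl on an amide-type nitrogen, so that isopropylcarbamoyl becomes carbamoyl. Within the data shown here, no pair of measured compounds isolates this change, so the data do not fix its size. In this assay a modest step is expected from the starting point of compound 1 at 8420 nM in the direction of a higher number and weaker inhibition of growth, although a step within the scatter would not be surprising. The estimated change is a 1.3-fold higher number from compound 1 to compound 4 (0.12 log units; within the scatter) and it remains only an expectation. The expected value for compound 4 is 11000 nM within an estimated range of 4000 nM to 30000 nM on repeated measurement.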

Compound 4, concentration for 50% growth inhibition: "not active" (no number reported)
Nothing numeric was reported for compound 4; the estimate stays without a comparison.
By their numbers in this assay, from the lowest: compounds 2 and 3 (each within the scatter of the next); then compound 1.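

In this assay, among these compounds, compound 4 is reported as "not active" without a number, so no step from compound 1 to compound 4 can be read. Nothing shown here offers an explanation for this result. The compounds shown leave open how large the change from isopropylcarbamoyl to carbamoyl is in this read-out.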